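Removing One Methoxy Group From a Weakly Active Compound

The source may hold more compounds than are shown below. What is called first, only, known or untested is meant among the compounds shown, and "the series" means these compounds.

Measured compounds:
- compound 1, `COc1cc(-c2cc(/C=C/C(=O)c3ccc(N)cc3)[nH]n2)cc(OC)c1OC`: > 100000 nM
- compound 2, `COc1ccc(-c2cc(/C=C/C(=O)c3ccc(OC)c(OC)c3)[nH]n2)cc1`: 9410 nM

Both measured compounds share one core and were tested in a functional assay on HCT-15 cells (Homo sapiens) for inhibition, read by sulforhodamine B assay, with a stated time of 48 h; a higher number here means that more compound is tolerated, a lower number that less compound is tolerated. For compound 1 the number given is not a measurement but a limit of the assay, > 100000 nM. That is the limit at which one of the two values sits, as the limit of > 100000 nM in this assay, at which 1 of the 2 values shown sits, shows. Compound 2, by contrast, gives a real number, 9410 nM. These two compounds differ from each other in several places at once, so the values alone cannot say which change accounts for the gap between them.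

Compound 3, `COc1ccc(-c2cc(/C=C/C(=O)c3ccc(N)cc3)[nH]n2)cc1OC`, differs from compound 1 in one place only: hydrogen in place of methoxy on an aromatic carbon. Within the data shown here, no measured pair shows what such a change does. Since compound 1 only sets a limit and the change is a small one, I expect the step of an at least 1.1-fold lower number from compound 1 to compound 3 (0.04 log units; that floor lies within the scatter) to stay within the scatter, with no clear direction. Compound 3 is therefore estimated at 90000 nM, with a range from 20000 nM to 300000 nM, and it may again be reported only as a limit.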

Compound 3, concentration lethal to 50% of the cells: 33000 nM
Compound 3: the middle estimate sits 2.7-fold (0.44 log units) above what was measured; low and high end bracket the measured number.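

Among these compounds, this is the first pair that differs in one place only, so the effect of hydrogen in place of methoxy on this aromatic carbon, ortho to a methoxy group and meta to a large group, can now be read on its own: in this assay the change gives an at least 3.0-fold lower number from compound 1 to compound 3 (0.48 log units; beyond the scatter), which shows that the methoxy group at this position is not needed for the effect on these cells and that the compound does better without it. Compound 1 is recorded only as a limit, > 100000 nM. The step can therefore be read for its direction and its smallest possible size, but not for its full size, because one of its two ends is not a real number: the limit of > 100000 nM in this assay, at which 1 of the 3 values shown sits.

What the compounds shown leave open is whether hydrogen is the best replacement at this carbon, since a hydroxyl group, a fluorine atom or an ethoxy group there might shift the number in either direction. This single pair also cannot say whether taking away either of the two remaining methoxy groups on that ring would give a step of similar size.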